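The compounds below may be only part of what the source reports. "The series", "measured", "known", "first", "only" and "open" are said of these compounds alone.

Values in a functional assay on the whole organism for antagonist activity, with Mus musculus as the target (on this read-out higher numbers stand for an effect only at larger amounts of compound and lower numbers for an effect already at smaller amounts), so far
- compound 1 `COC(=O)N(C)CC#CCn1cncc1C` gives 3 mg/kg
- compound 2 `CCOC(=O)N(C)CC#CCn1cncc1C` gives 66 mg/kg
- compound 3 `CN(C)C(=O)N(C)CC#CCn1ccnc1` gives 11.8 mg/kg

Compound 3 holds the middle number of the three, above compound 1 and below compound 2, with both gaps beyond the scatter. The change to compound 4 `Cc1cncn1CC#CCN(C)C(=O)N(C)C` is methyl in place of hydrogen on an aromatic carbon with methyl in place of hydrogen on an aromatic carbon. For the measured compounds named here, the one measured step, a 22-fold higher number from compound 1 to compound 2 (1.34 log units; beyond the scatter) and large, also adds a methyl, but on a saturated chain carbon bound to an oxygen next to a carbonyl group, so it gives no size for the ring change. It shows only that a single methyl can shift the number strongly in this series. Going by the values given here, compound 1 and compound 2 carry the ring methyl but also differ from compound 3 elsewhere, so no measured pair isolates it. In this assay no direction is supported, and the expected change is a 1.2-fold lower number from compound 3 to compound 4 (0.07 log units; within the scatter) at the centre, within the scatter, with wide margins. Compound 4 is estimated at 10 mg/kg with an expected range from 2.5 mg/kg to 40 mg/kg on present data.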

Compound 4, dose for half-maximal effect: 9.7 mg/kg
For compound 4 the middle estimate is 1.0-fold (0.01 log units) above the measured one, within the range that was stated.
By their numbers in this assay, from the lowest: compound 1; then compounds 4 and 3 (each within the scatter of the next); then compound 2.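

In this assay, methyl in place of hydrogen on the aromatic carbon next to the ring nitrogen leaves the number within the scatter (a 1.2-fold lower number from compound 3 to compound 4 (0.09 log units; within the scatter)), so with dimethylamino on the carbonyl carbon, this first isolated ring change shows no measurable effect. Compound 4 also allows direct comparison at the carbonyl carbon with the ring methyl held fixed: dimethylamino in place of ethoxy gives one step (a 6.8-fold lower number from compound 2 to compound 4 (0.83 log units; beyond the scatter)), and dimethylamino in place of methoxy gives a step in the opposite direction (a 3.2-fold higher number from compound 1 to compound 4 (0.51 log units; beyond the scatter)). No measurement available explains these steps.

Going by these compounds, it remains open whether ethyl or chlorine at this ring carbon would also leave the number unchanged. Also open, on these data alone, are the effect of the ring methyl with methoxy or ethoxy on the carbonyl carbon, and the effect of a pyrrolidine in place of dimethylamino.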